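Arylamine diaryl ether series: amine substituent variation

The source may report more compounds than this note shows. Statements on the series, on what has been measured and on what is new or still open speak of the compounds shown alone.

Measured compounds in a functional assay on SW-620 cells (Homo sapiens) for inhibition, read by MTT assay, with a stated time of 72 h; on this read-out lower numbers stand for stronger inhibition and higher numbers for weaker inhibition:
compound 1 `COc1cc(Oc2cccc(Nc3ccccc3)c2)cc(OC)c1CNCc1ccc(F)cc1` gives 6770 nM
compound 2 `COc1cc(Oc2cccc(Nc3ccccc3)c2)cc(OC)c1CNCCNC(C)=O` gives 11900 nM
compound 3 `COc1cc(Oc2cccc(Nc3ccccc3)c2)cc(OC)c1CN[C@H](C)c1ccccc1` gives 18700 nM

All three share the same core and differ only in the group on the amine nitrogen. For the measured compounds named here, compound 3 sits at the upper end of the numbers so far: against compound 2 the step of a 1.6-fold higher number from compound 2 to compound 3 (0.20 log units; within the scatter) is within the scatter, while against compound 1 the step of a 2.8-fold higher number from compound 1 to compound 3 (0.44 log units; beyond the scatter) is beyond it, so only the comparison with compound 1 carries weight.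

Compound 4 `COc1ccc(CCCNCc2c(OC)cc(Oc3cccc(Nc4ccccc4)c3)cc2OC)cc1` is the next member, not yet measured. The change from compound 3 is 3-(4-methoxyphenyl)propyl in place of 1-phenylethyl on an amine nitrogen. Going by the values given here, two measured steps bear on it. The step of a 2.8-fold higher number from compound 1 to compound 3 (0.44 log units; beyond the scatter) shows that the 1-phenylethyl group is the least favourable of the aryl-bearing substituents tried; the step of a 1.6-fold higher number from compound 2 to compound 3 (0.20 log units; within the scatter) shows that a flexible chain on the same nitrogen is no worse than 1-phenylethyl, and a 1.8-fold higher number from compound 1 to compound 2 (0.24 log units; within the scatter) places the flexible chain close to compound 1. Returning to a flexible chain that carries an aromatic ring is therefore expected to bring the number down somewhat, toward compound 1, though a move within the scatter is as likely as a modest one. The expected step is a 2.1-fold lower number from compound 3 to compound 4 (0.32 log units; beyond the scatter). Compound 4 is accordingly estimated at 9000 nM, with a range of 3500 nM to 25000 nM.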

Compound 4, half-maximal inhibitory concentration: 6400 nM
Estimate against measurement, compound 4: 1.4-fold (0.15 log units) above; low and high end bracket the measured number.
By their numbers in this assay, from the lowest: compounds 4, 1, 2 and 3 (each within the scatter of the next, the first and the last beyond it).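

In this assay, 3-(4-methoxyphenyl)propyl in place of 1-phenylethyl on the amine nitrogen gives a 2.9-fold lower number from compound 3 to compound 4 (0.47 log units; beyond the scatter) and shows that a flexible chain ending in an aromatic ring is tolerated here, leaving compound 3 at the high end, apart from compound 1 and compound 4 but not from compound 2. Lengthening the link to the ring while exchanging 4-fluorophenyl for a methoxy-bearing ring gives a 1.1-fold lower number from compound 1 to compound 4 (0.02 log units; within the scatter) and so no readable change, and the comparison with the acetamido chain, a 1.9-fold lower number from compound 2 to compound 4 (0.27 log units; within the scatter), is likewise flat, so the ring on the chain end makes no readable difference against the acetamido group in this pair. Nothing measured here speaks to the reason for these numbers.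

Compound 3 and compound 4 differ at once in the defined stereocentre, the chain length and the ring substituent, so an unsubstituted 3-phenylpropyl group or the opposite enantiomer of 1-phenylethyl would be needed to tell these apart. Also open, going by these compounds, is whether a carboxylic acid at the chain end, a longer chain or a tertiary amine at this nitrogen would move the number at all.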